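The compounds below may be only part of what the source reports. "The series", "measured", "known", "first", "only" and "open" are said of these compounds alone.

Measured so far
Compound 1, `C=Cc1cccc(-c2[nH]c3cc(OC)ccc3c(=O)c2C(=O)OCC)c1`: > 21500 nM
Compound 2, `CCOC(=O)c1c(-c2cccc(-c3ccccc3)c2)[nH]c2cc(OC)ccc2c1=O`: > 21500 nM

Compound 1, `C=Cc1cccc(-c2[nH]c3cc(OC)ccc3c(=O)c2C(=O)OCC)c1`, carries a vinyl group on the shared core. In an ADME assay on HepG2 cells (Homo sapiens) for cytotoxicity, read by luminescence, with a stated time of 72 h (a lower number here means that less compound is needed, a higher number that more compound is needed for the effect), compound 1 gives only a limit, > 21500 nM. Compound 2, `CCOC(=O)c1c(-c2cccc(-c3ccccc3)c2)[nH]c2cc(OC)ccc2c1=O`, has phenyl in place of vinyl on an aromatic carbon. In this assay compound 2 likewise gives only a limit, > 21500 nM. The step that the two limits leave unreadable from compound 1 to compound 2 therefore cannot be read in size or direction. Where compound 2 stands on the numbers shown is thus only a limit, and the one further value shown is a limit as well, because of the limit of > 21500 nM in this assay, at which 2 of the 2 values shown sit.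

The next compound, compound 3, `CCOC(=O)c1c(-c2cccc(OC(F)(F)F)c2)[nH]c2cc(OC)ccc2c1=O`, differs from compound 2 in one place: trifluoromethoxy in place of phenyl on an aromatic carbon. No measured step bears directly on a trifluoromethoxy group; the only step shown, from compound 1 to compound 2, is unreadable between its two limits. With both shown values sitting at the limit, the expectation for compound 3 is that it too stays at or beyond the limit, so the expected step that the limit leaves unreadable from compound 2 to compound 3 is none beyond the scatter. The estimate for compound 3 in this assay is 30000 nM, with a range from 10000 nM to 100000 nM.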

Compound 3, half-maximal effective concentration: > 21500 nM
Compound 3: no number, only a limit; the forecaster's own chance of this, stated with the estimate: 75%; the middle value does not contradict the limit.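

Compound 3 gives only a limit in this assay, > 21500 nM. Among these compounds, compound 1 and compound 2 also give only limits, so no step among compound 1, compound 2 and compound 3 can be read. The compounds shown leave open whether any group at this place on the shared core gives a readable number in this assay.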